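Cytotoxicity notes on compounds 1 to 4

This account rests on a few compounds, and the source may have more. Where it says the series, first, only, none or still open, it means among the compounds named here.

Measured compounds:
compound 1 `COC(=O)c1cc(-c2cccc(NC(=O)c3ccc(/C=C/C(=O)c4cccnc4)cc3)c2)on1` — "not determined" (no result reported)
compound 2 `COC(=O)c1cc(-c2cccc(NC(=O)c3ccc(/C=C/C(=O)c4cccc(C(F)(F)F)c4)cc3)c2)on1` — > 20 ug/mL, a limit of the assay, not a number
compound 3 `COC(=O)c1cc(-c2cccc(NC(=O)c3ccc(/C=C/C(=O)c4cccc([N+](=O)[O-])c4)cc3)c2)on1` — > 40 ug/mL, a limit of the assay, not a number

In an ADME assay on Vero cells (Chlorocebus sabaeus) for cytotoxicity, read by MTT assay, with a stated time of 72 h (a higher number here means that more compound is tolerated, a lower number that less compound is tolerated), compound 1 has no result of its own, so it cannot be placed among the two values that exist, both of which are limits rather than numbers. Compound 4 `COC(=O)c1cc(-c2cccc(NC(=O)c3ccc(/C=C/C(=O)c4ccc(C)c([N+](=O)[O-])c4)cc3)c2)on1` differs from compound 1 by 4-methyl-3-nitrophenyl in place of pyridin-3-yl on a carbonyl carbon.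

Among the measured compounds shown here, the only measured step in this assay, a step that the two limits leave unreadable from compound 2 to compound 3, bears on the kind of aromatic carbon substituent carried on the enone, but its size cannot be read because the limit of > 20 ug/mL in this assay, at which 1 of the 3 values shown sits, and the limit of > 40 ug/mL in this assay, at which 1 of the 3 values shown sits, are both limits and leave the true values open. For the measured compounds named here, no measured step touches the exchange of pyridin-3-yl for a carbon-only aromatic ring. Since every compound measured in this assay has so far been tolerated up to its limit, no step beyond the scatter is expected here, and a limit report is the likely outcome. Compound 4 is expected to give an estimated 40 ug/mL, within 15 ug/mL to 100 ug/mL, most likely again reported as a limit.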

Compound 4, half-maximal cytotoxic concentration: > 80 ug/mL
Compound 4: no number, only a limit (the forecaster's own chance of this, stated with the estimate: 75%); middle value at least 2.0-fold (0.30 log units) from the limit.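

In this assay compound 4 gives > 80 ug/mL, a limit and not a number. Among the compounds shown here, compound 2, compound 3 and compound 4 all stand as limits, so no step among them can be read. The compounds shown leave open their true values and where compound 1 stands.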